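Series notes: compound 3 against compounds 1 and 2

A few compounds are considered here, and "the series" means these few. Any claim that something is new, unique, unknown or untested is made for them only; others in the source may bear on it.

Compound 1 `COC(=O)/C=C/c1cccc(N(Cc2ccc(/C=C/c3ccc(F)cc3)cc2)C(=O)C(C)C)c1` gives 120 nM in an assay on isolated protein with Bile acid receptor (Homo sapiens) as the target; on this read-out higher numbers stand for an effect only at larger amounts of compound and lower numbers for an effect already at smaller amounts. Within the data shown here, compound 2 `COC(=O)/C=C/c1cccc(N(Cc2ccc(-c3ccc(N(C)C)cc3)cc2)C(=O)C(C)C)c1` gives 57 nM in this assay, the lowest of the two numbers measured so far; the one step available, a 2.1-fold lower number from compound 1 to compound 2 (0.32 log units; beyond the scatter), is modest. Compound 3 `COC(=O)/C=C/c1cccc(N(Cc2ccc(-c3cccc(OC)c3)cc2)C(=O)C(C)C)c1` carries 3-methoxyphenyl in place of 4-(dimethylamino)phenyl on an aromatic carbon. Among the measured compounds shown here, no measured step exchanges one substituted phenyl for another, so nothing bears on this change directly; the step of a 2.1-fold lower number from compound 1 to compound 2 (0.32 log units; beyond the scatter) shows only that altering the terminal aryl while the rest of the core stays fixed moved the number by a modest amount. On that basis the change a 1.4-fold higher number from compound 2 to compound 3 (0.15 log units; within the scatter) is expected to be small, close to or within the usual scatter, with a slight lean toward a higher number. The estimate for compound 3 in this assay is 80 nM, with a range from 30 nM to 220 nM.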

Compound 3, half-maximal effective concentration: 72 nM
Compound 3: the middle estimate sits 1.1-fold (0.05 log units) above what was measured, within the range that was stated.
By their numbers in this assay, from the lowest: compounds 2, 3 and 1 (each within the scatter of the next, the first and the last beyond it).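

In this assay, a 1.3-fold higher number from compound 2 to compound 3 (0.10 log units; within the scatter), so on an aromatic carbon para to a large group, 3-methoxyphenyl cannot be told apart from 4-(dimethylamino)phenyl, and the dimethylamino group is not required for a number in this range. With a 1.7-fold lower number from compound 1 to compound 3 (0.22 log units; within the scatter) also within the scatter, compound 3 cannot be separated from compound 1 either, although a 2.1-fold lower number from compound 1 to compound 2 (0.32 log units; beyond the scatter) separates compound 1 and compound 2, so compound 3 does not sharpen the difference between those two. No data at hand explain these numbers.

Going by these compounds, the exchange alters both the substituent and its place on the terminal ring, so the separate contribution of each remains open; 4-methoxyphenyl would separate them. On these data alone, how this position responds to a carboxylic acid or a primary amine on that ring also remains open.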